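The source may hold more compounds than are shown below. What is called first, only, known or untested is meant among the compounds shown, and "the series" means these compounds.

Compound 1, `CCN(CC)CCNC(=O)c1ccc(C(CC)(CC)c2ccc(OCCC(O)(CC)CC)c(C)c2)n1CC`: in an assay on cells for agonist activity at vitamin D3 receptor (Homo sapiens), with a stated time of 96 h (a lower number here means that less compound is needed, a higher number that more compound is needed for the effect), compound 1 gives 2.3 nM.
Compound 2, `CCn1c(C(=O)NCC#N)ccc1C(CC)(CC)c1ccc(OCCC(O)(CC)CC)c(C)c1`: in this assay compound 2 gives 1080 nM.
Compound 3, `CCOC(=O)C(CC(=O)OC)NC(=O)c1ccc(C(CC)(CC)c2ccc(OCCC(O)(CC)CC)c(C)c2)n1CC`: in this assay compound 3 gives 21 nM.

Compound 3 holds the second highest of the three numbers. Its nearer neighbour is reached by the step of a 9.1-fold higher number from compound 1 to compound 3 (0.96 log units; beyond the scatter), a modest one, and its farther neighbour by the step of a 51-fold lower number from compound 2 to compound 3 (1.71 log units; beyond the scatter), a large one. Compound 4, `CCn1c(C(=O)N(C)CC(=O)O)ccc1C(CC)(CC)c1ccc(OCCC(O)(CC)CC)c(C)c1`, differs from compound 3 in one place: a group of 6 heavy atoms (3 carbon, 1 nitrogen, 2 oxygen; no ring) in place of a group of 12 heavy atoms (7 carbon, 1 nitrogen, 4 oxygen; no ring), on a carbonyl carbon. All three measured steps bear on this change, since each alters the substituent on the amide: a 470-fold higher number from compound 1 to compound 2 (2.67 log units; beyond the scatter) and the two steps just named. They show that this position is sensitive, with the smallest group giving the highest number and the two larger groups the two lower numbers. Because compound 2 gives 1080 nM with a small group while compound 3 gives 21 nM, a higher number is expected for compound 4, as a modest step, a 3.8-fold higher number from compound 3 to compound 4 (0.58 log units; beyond the scatter). Compound 4 is therefore estimated at 80 nM, within a range of 12 nM to 500 nM.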

Compound 4, half-maximal effective concentration: 89 nM
The estimate for compound 4 lay 1.1-fold (0.05 log units) below the measured number; low and high end bracket the measured number.
By their numbers in this assay, from the lowest: compound 1; then compound 3; then compound 4; then compound 2.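

Replacing the group on the carbonyl carbon with (carboxymethyl)(methyl)amino gives a 12-fold lower number from compound 2 to compound 4 (1.08 log units; beyond the scatter) in this assay, so this group retains far more of the effect than (cyanomethyl)amino does. It still falls short of the two other groups, with a 4.2-fold higher number from compound 3 to compound 4 (0.63 log units; beyond the scatter) and a 39-fold higher number from compound 1 to compound 4 (1.59 log units; beyond the scatter). The order of the four compounds therefore does not follow group size alone: the group in compound 4 is smaller than that in compound 3 and gives a higher number, as the size trend suggests, but compound 1 goes against that trend, holding the lowest number with a smaller group than compound 3. No measurement offered here explains these differences. Compound 4 differs from compound 2 in both the methyl on the amide nitrogen and the carboxylic acid, and the shown compounds cannot separate the two, as a comparison with (carboxymethyl)amino could.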